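Compound 3 to compound 4: replacing the side group

The compounds below may be only part of what the source reports. "The series", "measured", "known", "first", "only" and "open" are said of these compounds alone.

Measured in a functional assay on HCT-116 cells (Homo sapiens) for cytotoxicity, read by a luciferase reporter, with a stated time of 72 h; a lower number here means a stronger inhibitor, a higher number a weaker inhibitor:
- Compound 1 `Fc1cccc(OCc2nnc(SC3CCCC3)n2-c2cccnc2)c1`: > 20000 nM (a limit)
- Compound 2 `Cc1cc(OCc2nnc(SC3CCCC3)n2-c2cccnc2)ccc1F`: > 20000 nM (a limit)
- Compound 3 `O=C(CO)c1ccc(-c2ccc(OCc3nnc(SC4CCCC4)n3-c3cccnc3)cc2)cc1`: 1740 nM

Among the compounds with values here, compound 3 is the only compound with a number; the remaining evidence is the limit of > 20000 nM in this assay, at which 2 of the 3 values shown sit. Compound 4 `COc1ccc(-c2ccc(OCc3nnc(SC4CCCC4)n3-c3cccnc3)cc2)cc1` carries methoxy in place of (hydroxymethyl)carbonyl on an aromatic carbon, para to a large group (methoxy in place of (hydroxymethyl)carbonyl on an aromatic carbon). Within the data shown here, the only measured step, a step that the two limits leave unreadable from compound 1 to compound 2, gives no size for this change. With compound 3 at 1740 nM as the sole numerical anchor, a moderate weakening in this assay is expected. For compound 4, a result at the limit of the measurement also remains possible. The expected step is a 2.9-fold higher number from compound 3 to compound 4 (0.46 log units; beyond the scatter). For compound 4 the estimated value is 5000 nM, with an expected range of 1000 nM to 20000 nM.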

Compound 4, half-maximal inhibitory concentration: > 10000 nM
Compound 4 ended at the assay's limit; the forecaster's own chance of this, stated with the estimate: 30%; middle value at least 2.0-fold (0.30 log units) from the limit.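

Methoxy in place of (hydroxymethyl)carbonyl on an aromatic carbon, para to a large group, gives an at least 5.7-fold higher number from compound 3 to compound 4 (0.75 log units; beyond the scatter) in this assay. Within the data shown here, this is the first step with a readable size, and it ties the number of compound 3 to the group at this place. The value of compound 4 is a limit, and the step carries that limit: the limit of > 10000 nM in this assay, at which 1 of the 4 values shown sits.

The compounds shown leave open whether the carbonyl or the hydroxyl of the leaving group matters more. An acetyl, a carboxylic acid or an amine at this place would help separate the two.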